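The source may hold more compounds than are shown below. What is called first, only, known or untested is meant among the compounds shown, and "the series" means these compounds.

Measured compounds in this series:
- compound 1 `CCn1c(C(=O)NCC(OC)OC)ccc1C(CC)(CC)c1ccc(OCC(=O)C(C)(C)C)c(C)c1`: 130 nM
- compound 2 `CCn1c(C(=O)NCC(OC)OC)ccc1C(CC)(CC)c1ccc(OCC(O)C(C)(C)C)c(C)c1`: 150 nM
- compound 3 `CC[C@@H](C)[C@H](NC(=O)c1ccc(C(CC)(CC)c2ccc(OCC(O)C(C)(C)C)c(C)c2)n1CC)C(=O)O`: 2.3 nM

Compound 1 stands second highest of the three numbers in an assay on HL-60 cells for agonist activity at vitamin D3 receptor (Homo sapiens), read by microscopy, with a stated time of 96 h; on this read-out higher numbers stand for an effect only at larger amounts of compound and lower numbers for an effect already at smaller amounts. Its nearest neighbour is compound 2, which gives 150 nM, a difference that is a 1.2-fold higher number from compound 1 to compound 2 (0.06 log units; within the scatter). Among the measured compounds shown here, the furthest is compound 3, with 2.3 nM; the step of a 65-fold lower number from compound 2 to compound 3 (1.81 log units; beyond the scatter) is the only large change seen so far, and it comes from what sits on the amide-type nitrogen rather than from the side chain on the aromatic ring.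

Compound 4 `CCOC(=O)c1ccc(OC(=O)c2ccc(C(CC)(CC)c3ccc(OCC(=O)C(C)(C)C)c(C)c3)n2CC)cc1` has not yet been measured. Relative to compound 1 the difference is 4-(ethoxycarbonyl)phenoxy in place of (2,2-dimethoxyethyl)amino on a carbonyl carbon. For the measured compounds named here, no measured pair changes the carbonyl carbon in this way, and compound 3 shows only that the group on that carbonyl can move the number a great deal. The 1-carboxy-2-methylbutyl group of compound 3 carries a hydrogen-bond donor, whereas the entering 4-(ethoxycarbonyl)phenoxy group carries none, so the direction of the step of a 65-fold lower number from compound 2 to compound 3 (1.81 log units; beyond the scatter) cannot be transferred with confidence. Compound 4 is therefore expected to give about 120 nM, within 25 nM to 600 nM, a step of a 1.1-fold lower number from compound 1 to compound 4 (0.03 log units; within the scatter) that is estimated to stay within the scatter.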

Compound 4, half-maximal effective concentration: 45600 nM
For compound 4 the middle estimate is 380-fold (2.58 log units) below the measured one; the measured number lies above the stated range.
By their numbers in this assay, from the lowest: compound 3; then compounds 1 and 2 (each within the scatter of the next); then compound 4.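

In this assay the group on the carbonyl carbon moves the number in both directions: 4-(ethoxycarbonyl)phenoxy in place of (2,2-dimethoxyethyl)amino gives a 350-fold higher number from compound 1 to compound 4 (2.55 log units; beyond the scatter), while the earlier change on the amide-type nitrogen gave a 65-fold lower number from compound 2 to compound 3 (1.81 log units; beyond the scatter), so this place in the series is not merely tolerant of replacement with an occasional gain. The new step changes several things at once: the atom bound to the carbonyl carbon goes from nitrogen to oxygen, the amide hydrogen is lost with the only hydrogen-bond donor of the leaving group, and a six-membered aromatic ring of carbon enters along with a larger group overall, and a single pair cannot separate these changes. Nothing among the data shown accounts for the size or direction of this step.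

Still open, going by these compounds, is which of these changes carries the step: a (4-(ethoxycarbonyl)phenyl)amino group on the same carbonyl carbon would keep the nitrogen and the ring together, and a plain phenoxy group would test the ring without the ethoxycarbonyl. Also open, on these data alone, is whether a 4-carboxyphenoxy group, with a carboxylic acid like that of compound 3, behaves as 4-(ethoxycarbonyl)phenoxy does.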